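The source may hold more compounds than are shown below. What is called first, only, known or untested is meant among the compounds shown, and "the series" means these compounds.

Measured in a functional assay on Jurkat cells (Homo sapiens) for inhibition, read by MTT assay, with a stated time of 72 h; a lower number here means a stronger inhibitor, a higher number a weaker inhibitor:
- compound 1 `CO[C@@H]1[C@H]2OC(=O)C[C@H]2O[C@@H]1[C@@H](O)c1ccccc1`: 15500 nM
- compound 2 `CO[C@@H]1[C@H]2OC(=O)C[C@H]2O[C@@H]1C(O)(c1ccccc1)c1ccccc1`: 9790 nM
- compound 3 `CO[C@@H]1[C@H]2OC(=O)C[C@H]2O[C@@H]1[C@H](O)c1ccccc1`: 24900 nM

On these numbers, compound 1 stands among the other two, and its gap to each is within the scatter. So compound 1 gives no clear order against either neighbour.

The next compound, compound 4 `CO[C@@H]1[C@H]2OC(=O)C[C@H]2O[C@@H]1[C@@H](OC)c1ccccc1`, keeps the core of compound 1 and has methyl in place of hydrogen on an oxygen on a saturated carbon, which reads as hydroxy to methoxy (methyl in place of hydrogen on an oxygen on a saturated carbon).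

Among the compounds with values here, only one measured step links two compounds by a single difference: a 1.6-fold higher number from compound 1 to compound 3 (0.21 log units; within the scatter). There, only the configuration as drawn changes (the fact that compounds 1 and 3 differ only in the configuration as drawn), at a saturated chain carbon. That step is within the scatter, and it does not test a methyl group at all, so it is weak guidance. Within the data shown here, no measured step makes the hydroxy to methoxy exchange, so the direction of any change is open.

In this assay, the working expectation is therefore no shift beyond the scatter, with a wide margin for the untested change. The expected step is a 1.1-fold lower number from compound 1 to compound 4 (0.04 log units; within the scatter). For compound 4, the estimated value is 14000 nM, with an expected range from 5000 nM to 35000 nM.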

Compound 4, half-maximal inhibitory concentration: 1690 nM
Estimate against measurement, compound 4: 8.3-fold (0.92 log units) above, and the stated range ends above it.
By their numbers in this assay, from the lowest: compound 4; then compounds 2, 1 and 3 (each within the scatter of the next, the first and the last beyond it).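

In this assay, the hydroxy to methoxy exchange on this oxygen gives a 9.2-fold lower number from compound 1 to compound 4 (0.96 log units; beyond the scatter) and so shows that one added methyl here can move the number beyond the scatter, which no earlier comparison had shown. Within the data shown here, the only earlier step between compounds that differ in one place, a 1.6-fold higher number from compound 1 to compound 3 (0.21 log units; within the scatter) and within the scatter, kept the hydrogen on this oxygen, whereas the new step shows that compound 1 does not need that hydrogen to give a number this low in this assay. Nothing measured here explains why the methyl has this effect.

From the compounds shown here alone, it remains open whether the same exchange would give a step of similar size in the other configuration, starting from compound 3. Going by these compounds, it is also open whether the lower number is particular to methyl or would persist with a longer chain such as ethyl or benzyl on this oxygen, or with an amine in place of the hydroxy.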